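This account rests on a few compounds, and the source may have more. Where it says the series, first, only, none or still open, it means among the compounds named here.

Measured in a functional assay on A549 cells (Homo sapiens) for cytotoxicity, read by MTT assay, with a stated time of 68 h; a lower number here means a stronger inhibitor, a higher number a weaker inhibitor:
- compound 1 `Nc1cccc(-c2cccc(NC(=O)C(Cl)Cl)c2)c1` gives 50000 nM
- compound 2 `O=C(Nc1cccc(-c2ccccc2C(F)(F)F)c1)C(Cl)Cl` gives 7500 nM
- compound 3 `CCOc1ccccc1-c1cc(NC(=O)C(Cl)Cl)cc(-c2ccccc2OCC)c1` gives 7280 nM

Compound 1 gives the highest number of the three, and the gaps from it down to compound 2 and to compound 3 both lie beyond the usual scatter. The next compound to be tested is compound 4 `COc1cccc(-c2cccc(NC(=O)C(Cl)Cl)c2)c1`, which keeps the core of compound 1 and carries methoxy in place of amino on an aromatic carbon, meta to a large group. That change is methoxy in place of amino on an aromatic carbon and it is the only one.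

Among the measured compounds shown here, no two measured compounds differ in a single place, so the change has no direct precedent here. The nearest guide is indirect: compound 2 at 7500 nM and compound 3 at 7280 nM also have no amino group, although neither has the substitution found in compound 4. In this assay a moderate fall beyond the scatter is therefore expected, though a smaller step cannot be ruled out. The estimated step is a 4.2-fold lower number from compound 1 to compound 4 (0.62 log units; beyond the scatter) in this direction. For compound 4 the expected value is 12000 nM with an estimated range from 5000 nM to 30000 nM before any measurement.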

Compound 4, half-maximal inhibitory concentration: 4310 nM
Estimate against measurement, compound 4: 2.8-fold (0.44 log units) above, outside the stated range (below it).
By their numbers in this assay, from the lowest: compounds 4, 3 and 2 (each within the scatter of the next); then compound 1.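

In this assay, methoxy in place of amino on an aromatic carbon, meta to a large group, gives a 12-fold lower number from compound 1 to compound 4 (1.06 log units; beyond the scatter), a large step and the only one shown in which a single place changes while the core of compound 1 stays the same. The earlier compounds shown here differ from compound 1 in more than one place, so they could not tie any shift in the number to this position; this pair shows that the exchange at this carbon alone is enough to produce a step well beyond the scatter. The exchange removes a hydrogen-bond donor and adds a heavy atom, but no measurement shown explains why the number falls.

Among the compounds shown here, the single pair cannot separate the departure of amino from the arrival of methoxy, and what a hydroxyl group, an ethoxy group or a plain hydrogen would give on this same carbon remains open. On these data alone, it is also open whether methoxy would give a step of similar size elsewhere on this ring, or on a core bearing a different group at the dichloroacetamide end.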